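A few compounds are considered here, and "the series" means these few. Any claim that something is new, unique, unknown or untested is made for them only; others in the source may bear on it.

Compound 1 `O=C1C=C(N2CCN(c3ccccc3)CC2)C(=O)c2ccccc21`, compound 2 `COc1ccccc1N1CCN(C2=CC(=O)c3ccccc3C2=O)CC1`, compound 3 `COc1ccc(N2CCN(C3=CC(=O)c4ccccc4C3=O)CC2)cc1OC` and compound 4 `COc1cc(N2CCN(C3=CC(=O)c4ccccc4C3=O)CC2)cc(OC)c1OC` share one core. In a functional assay on DU-145 cells (Homo sapiens) for inhibition, read by MTT assay, with a stated time of 72 h (on this read-out lower numbers stand for stronger inhibition and higher numbers for weaker inhibition), compound 1 gives 9900 nM, and compound 2 gives 8000 nM; the step of a 1.2-fold lower number from compound 1 to compound 2 (0.09 log units; within the scatter) came from methoxy in place of hydrogen on an aromatic carbon. Compound 3 gives 17800 nM; how its core differs from that of compound 1 is not broken down here. Compound 4 carries methoxy in place of hydrogen on an aromatic carbon. This is the same kind of change as from compound 1 to compound 2, but the place differs: there the new group sat ortho to a large group, here it sits ortho to a methoxy group, meta to a large group and meta to a methoxy group. Since the earlier step was a 1.2-fold lower number from compound 1 to compound 2 (0.09 log units; within the scatter), a step of a 1.1-fold lower number from compound 3 to compound 4 (0.05 log units; within the scatter) is expected. Compound 4 is therefore estimated at 16000 nM, between 7000 nM and 40000 nM.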

Compound 4, half-maximal inhibitory concentration: 11600 nM
Compound 4: the middle estimate sits 1.4-fold (0.14 log units) above what was measured, within the range that was stated.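

In this assay, methoxy in place of hydrogen on an aromatic carbon gives a 1.5-fold lower number from compound 3 to compound 4 (0.19 log units; within the scatter), and the two cores do not differ in this respect: the same change on two cores in this assay, a 1.2-fold lower number (0.09 log units; within the scatter) from compound 1 to compound 2 and a 1.5-fold lower number (0.19 log units; within the scatter) from compound 3 to compound 4, 1.2-fold (0.09 log units) apart, within the scatter of two such steps. The change therefore carries from one core to the other in the limited sense that neither step can be told apart from repeat measurement, even though the new group sits in a different place in each case. For the compounds shown here, this does not show that methoxy has a real effect of a set size that transfers between cores, and it rests on only two pairs.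

Still open, going by these compounds, is whether an amine or a carboxylic acid on the aromatic carbon would give a step beyond the scatter. A longer chain in place of methoxy is equally untested among the compounds shown.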